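Notes on the step from compound 3 to compound 4

The compounds below may be only part of what the source reports. "The series", "measured", "known", "first", "only" and "open" are said of these compounds alone.

Measured in an ADME assay on CCRF-CEM cells (Homo sapiens) for cytotoxicity, with a stated time of 5 days (a higher number here means a weaker inhibitor, a lower number a stronger inhibitor), all values being limits:
- compound 1 `C=CCNc1nc(N)nc2c1ncn2[C@H]1C[C@H](N=[N+]=[N-])[C@@H](CO)O1` gives > 100000 nM
- compound 2 `[N-]=[N+]=N[C@H]1C[C@H](n2cnc3c(NC4CC4)nc(N)nc32)O[C@@H]1CO` gives > 100000 nM
- compound 3 `C#CCNc1nc(N)nc2c1ncn2[C@H]1C[C@H](N=[N+]=[N-])[C@@H](CO)O1` gives > 100000 nM

Compound 3 gives > 100000 nM, which is a limit and not a number. Compound 1 and compound 2 also give only limits, so compound 3 cannot be ranked against either. The whole measured set shares one boundary: the limit of > 100000 nM in this assay, at which 3 of the 3 values shown sit.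

Compound 4 `[N-]=[N+]=N[C@H]1C[C@H](n2cnc3c(NCCO)nc(N)nc32)O[C@@H]1CO` is the next member, with this change: hydroxymethyl in place of ethynyl on a saturated chain carbon bound to a nitrogen on an aromatic ring. In words, this is hydroxymethyl in place of ethynyl on a saturated chain carbon bound to a nitrogen on an aromatic ring, or propargyl to 2-hydroxyethyl.

Among the measured compounds shown here, two measured steps bear on it: a step that the two limits leave unreadable from compound 1 to compound 3 changes the same place, and a step that the two limits leave unreadable from compound 2 to compound 3 changes the same nitrogen substituent. Neither has a readable size, and no substituent tried so far has left the limit in this assay. No step beyond the scatter is therefore expected, and no direction can be assigned to the expected a number no higher from compound 3 to compound 4 (the limit leaves the size open). Compound 4 is estimated at 100000 nM, within an expected range of 40000 nM to 200000 nM.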

Compound 4, half-maximal inhibitory concentration: > 100000 nM
Compound 4: no number, only a limit (the forecaster's own chance of this, stated with the estimate: 85%); the middle value sits exactly at the limit.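

In this assay compound 4 gives > 100000 nM, a limit and not a number. No step can be read between compound 4 and compound 1, compound 2 or compound 3, all sharing one boundary: the limit of > 100000 nM in this assay, at which 4 of the 4 values shown sit.

The compounds shown leave open how far each lies beyond that limit, and so how these nitrogen substituents rank.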